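Sulfonamide series: from 3-chlorophenyl to 3-methoxyphenyl

The compounds below may be only part of what the source reports. "The series", "measured", "known", "first", "only" and "open" are said of these compounds alone.

Measured so far in a functional assay on MDA-MB-231 cells (Homo sapiens) for antiproliferative activity, read by sulforhodamine B assay, with a stated time of 48 h; a lower number here means a stronger inhibitor, a higher number a weaker inhibitor:
- compound 1 `Cc1cc(C)cc(NS(=O)(=O)c2ccc(N3CCNC3=O)cc2)c1` gives 1220 nM
- compound 2 `O=C1NCCN1c1ccc(S(=O)(=O)Nc2cccc(Cl)c2)cc1` gives 200 nM

Of the two measured compounds, compound 2 has the lower number, and the gap to compound 1 is beyond the scatter. Next is compound 3 `COc1cccc(NS(=O)(=O)c2ccc(N3CCNC3=O)cc2)c1`, which differs from compound 2 as follows: methoxy in place of chloro on an aromatic carbon. Among the compounds with values here, one measured step bears on this, a 6.1-fold lower number from compound 1 to compound 2 (0.79 log units; beyond the scatter). Within the data shown here, it is modest and involves the same aryl group, but it is a different change, and no measured compound carries methoxy. It therefore gives a rough size for changes here, not a direction. Among the measured compounds shown here, a somewhat higher number in this assay is expected, no larger than that step, though this is a cautious judgement from two compounds. The expected step is a 1.9-fold higher number from compound 2 to compound 3 (0.28 log units; within the scatter). For compound 3 the estimated value is 380 nM, with an expected range of 120 nM to 1200 nM.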

Compound 3, half-maximal inhibitory concentration: 730 nM
Beside the measured number, compound 3's estimate is 1.9-fold (0.28 log units) below it; the range from low to high includes it.
By their numbers in this assay, from the lowest: compound 2; then compounds 3 and 1 (each within the scatter of the next).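

In this assay, the aromatic carbon meta to a large group now has a direct comparison of two single groups, with a 3.7-fold higher number from compound 2 to compound 3 (0.56 log units; beyond the scatter) when methoxy replaces chloro, so this position responds to the identity of the group and not merely to the presence of one. The 3-methoxyphenyl group does not separate from the 3,5-dimethylphenyl group, with a 1.7-fold lower number from compound 1 to compound 3 (0.22 log units; within the scatter), which leaves compound 2 alone with a number clearly apart from the other two. Nothing measured here accounts for the gap between chloro and methoxy.

Open, as far as these compounds go, is how a bromo, an amine or a carboxylic acid on this aromatic carbon would compare with chloro. Also open, from the compounds shown here alone, is how changes to the shared core would read, since all three compounds keep it unchanged.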